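The source may hold more compounds than are shown below. What is called first, only, known or untested is meant among the compounds shown, and "the series" means these compounds.

Within the data shown here, compound 2 `Oc1ccc(-c2cc(-c3ccccc3C(F)(F)F)cc(-c3cccc(O)c3)n2)cc1` is the only member of this set with a number in a functional assay on T47D cells (Homo sapiens) for inhibition (on this read-out lower numbers stand for stronger inhibition and higher numbers for weaker inhibition), where compound 2 gives 3210 nM. Compound 1 `Oc1ccc(-c2cc(-c3cccc(F)c3)cc(-c3ccc(O)cc3)n2)cc1` reaches only a limit in this assay, with compound 1 recorded as > 50000 nM. Compound 3 `Oc1ccc(-c2cc(-c3ccccc3C(F)(F)F)cc(-c3ccc(O)cc3)n2)cc1` is not yet measured; it differs from compound 2 by 4-hydroxyphenyl in place of 3-hydroxyphenyl on an aromatic carbon. Compound 3 thereby carries two 4-hydroxyphenyl groups, as compound 1 does. Given the limit of > 50000 nM in this assay, at which 1 of the 2 values shown sits, for compound 1, which shares that arrangement, compound 3 is expected to weaken beyond the scatter, a step of a 3.7-fold higher number from compound 2 to compound 3 (0.57 log units; beyond the scatter). Compound 3 is therefore estimated at 12000 nM, within a range from 3500 nM to 50000 nM.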

Compound 3, half-maximal inhibitory concentration: > 50000 nM
Compound 3 gave a limit, no number; the forecaster's own chance of this, stated with the estimate: 30%; middle value at least 4.1-fold (0.61 log units) away from the limit.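

In this assay, with the 2-(trifluoromethyl)phenyl group held constant, 4-hydroxyphenyl in place of 3-hydroxyphenyl next to the ring nitrogen gives an at least 15-fold higher number from compound 2 to compound 3 (1.19 log units; beyond the scatter). Among these compounds, this is the first single change in the set, and it shows that the location of the hydroxyl on this ring alone separates a measurable value from a limit. Compound 3 stands at a limit of the assay, as compound 1 does, so the step between them cannot be read.

As far as these compounds go, how far compound 3 lies past its limit stays open. So does whether a methoxy or an amine in place of that hydroxyl would keep the activity of compound 2.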